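Same change, same core: a benzylamine pKa reading

This account rests on a few compounds, and the source may have more. Where it says the series, first, only, none or still open, it means among the compounds named here.

Compound 1 `COc1cccc(CNCCCNc2ccnc3cc(-c4ccc(F)cc4)ccc23)c1O` gives 9.47 in a physicochemical assay for acid dissociation. Compound 2 `COc1ccc(F)cc1CNCCCNc1ccnc2cc(-c3ccc(F)cc3)ccc12` gives 9.47 in this assay. Compound 3 `COc1ccc(F)cc1CNCCCNc1ccnc2cc(-c3ccc(C(F)(F)F)cc3)ccc12` gives 9.47 in this assay.

The three measured compounds sit on two closely related cores. Compound 1 and compound 2 share one core and differ by 2-hydroxy-3-methoxyphenyl in place of 5-fluoro-2-methoxyphenyl on a saturated chain carbon bound to an amine nitrogen; this change made the step of no change at the digits printed from compound 2 to compound 1 (within the scatter). Compound 2 and compound 3 differ in the core by trifluoromethyl in place of fluoro on an aromatic carbon, and that gave no change at the digits printed from compound 2 to compound 3 (within the scatter). Compound 4 `COc1cccc(CNCCCNc2ccnc3cc(-c4ccc(C(F)(F)F)cc4)ccc23)c1O` is not yet measured. It stands on the core of compound 3 and differs from it by 2-hydroxy-3-methoxyphenyl in place of 5-fluoro-2-methoxyphenyl on a saturated chain carbon bound to an amine nitrogen, which is the same change already seen from compound 2 to compound 1, on the same place word for word. Because the same change gave no change at the digits printed from compound 2 to compound 1 (within the scatter), and because the core difference gave no change at the digits printed from compound 2 to compound 3 (within the scatter), the step from compound 3 to compound 4 in this assay is expected to be no change at the digits printed from compound 3 to compound 4 (within the scatter), again within the scatter. Compound 4 is therefore estimated at 9.47, with a range from 9.2 to 9.75.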

Compound 4, acid dissociation constant: 9.47
Compound 4: middle estimate and measured number agree at the digits printed; low and high end bracket the measured number.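

In this assay, placing 2-hydroxy-3-methoxyphenyl in place of 5-fluoro-2-methoxyphenyl on the core of compound 3 gave no change at the digits printed from compound 3 to compound 4 (within the scatter), the same outcome as no change at the digits printed from compound 2 to compound 1 (within the scatter) on the other core, while the second side of the square, trifluoromethyl in place of fluoro, gave no change at the digits printed from compound 1 to compound 4 (within the scatter) in this pair. Going by these compounds alone, this shows that, across these four compounds, the change carried from one core to the other with the same null outcome, but it does not show that a step of real size would carry over in the same way, since no step here stands beyond the scatter. Nothing measured here speaks to why the four readings are level.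

From the compounds shown here alone, whether the readings stay level with a nitrile in place of trifluoromethyl on the aromatic carbon remains open. So does the outcome of the same change on a core with a longer chain in place of the present one, or with a carboxylic acid on the benzyl group.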